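Swapping the aryl group on the hydrazone carbon: compound 3

The source may hold more compounds than are shown below. What is called first, only, known or untested is meant among the compounds shown, and "the series" means these compounds.

Two compounds of this series share a common core and differ only in the aromatic ring attached to a carbon with a double bond to nitrogen. Compound 1 `O=C(CSc1nnc(-c2ccncc2)o1)N/N=C/c1ccc(Cl)cc1` carries a 4-chlorophenyl group there, and in a functional assay on HepG2 cells (Homo sapiens) for cytotoxicity, read by MTT assay, with a stated time of 48 h (a higher number here means a weaker inhibitor, a lower number a stronger inhibitor), compound 1 gives 15700 nM. Going by the values given here, compound 2 `O=C(CSc1nnc(-c2ccncc2)o1)N/N=C/c1cc(Br)ccc1O` carries a 5-bromo-2-hydroxyphenyl group instead, and in this assay compound 2 gives 6490 nM, the lowest of the two numbers so far. The step of a 2.4-fold lower number from compound 1 to compound 2 (0.38 log units; beyond the scatter) shows that changing this ring moves the number by a modest amount.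

Compound 3 `COc1cc(/C=N/NC(=O)CSc2nnc(-c3ccncc3)o2)ccc1O` makes a further exchange at the same place: 4-hydroxy-3-methoxyphenyl in place of 5-bromo-2-hydroxyphenyl on a carbon with a double bond to nitrogen. Among the compounds with values here, no measured step exchanges a 5-bromo-2-hydroxyphenyl for a 4-hydroxy-3-methoxyphenyl, so the only guide is that the single known ring swap was modest. A change of similar size, in either direction or none beyond the scatter, is therefore expected. For compound 3 in this assay the estimate is 9000 nM, with a range from 3000 nM to 30000 nM, meaning an expected step of a 1.4-fold higher number from compound 2 to compound 3 (0.14 log units; within the scatter).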

Compound 3, half-maximal inhibitory concentration: 2920 nM
For compound 3 the middle estimate is 3.1-fold (0.49 log units) above the measured one; the measured number lies below the stated range.
By their numbers in this assay, from the lowest: compound 3; then compound 2; then compound 1.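

In this assay the ring on the carbon with a double bond to nitrogen can shift the number further than the first swap suggested: the step of a 2.2-fold lower number from compound 2 to compound 3 (0.35 log units; beyond the scatter) comes on top of a wider overall step of a 5.4-fold lower number from compound 1 to compound 3 (0.73 log units; beyond the scatter) within this set of three rings. Compound 3 has the lowest number of the three and carries no halogen, whereas compound 1 has chlorine and compound 2 has bromine, so among these compounds a halogen on this ring is not required for the lowest number. Nothing measured here explains why the 4-hydroxy-3-methoxyphenyl ring gives the lowest number.

Each swap changes more than one feature of the ring at once, so these three compounds cannot separate the contribution of the hydroxyl, the methoxy group and the halogens. A plain 4-hydroxyphenyl ring would test the hydroxyl without the methoxy group, and a ring bearing an amine or a carboxylic acid would show how this position responds to groups quite unlike those seen so far.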